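Dropping the methoxy: a selenium compound expected to stay non-cytotoxic

The source may hold more compounds than are shown below. What is called first, only, known or untested is meant among the compounds shown, and "the series" means these compounds.

Compound 2 `COc1ccc(CNc2nc([SeH])nc3ccccc23)cc1` stands at the edge of what the measurements can show. In an ADME assay on BEAS-2B cells (Homo sapiens) for cytotoxicity, read by MTT assay, with a stated time of 72 h (a lower number here means a stronger inhibitor of growth, a higher number a weaker inhibitor of growth), compound 2 gives > 100000 nM, which is a limit of the assay rather than a number. Its methylated neighbour, compound 1 `COc1ccc(CNc2nc([Se]C)nc3ccccc23)cc1`, is no different in kind: in this assay compound 1 gives > 100000 nM, again a limit. The same holds for compound 3 `[SeH]c1nc(NCc2ccccc2)c2cccnc2n1`, which in this assay gives > 100000 nM, also a limit. Going by the values given here, the only step with both ends measured, a step that the two limits leave unreadable from compound 1 to compound 2, is therefore unreadable, because the limit of > 100000 nM in this assay, at which 3 of the 3 values shown sit, describes every value shown.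

Compound 4 `[SeH]c1nc(NCc2ccccc2)c2ccccc2n1` differs from compound 2 by hydrogen in place of methoxy on an aromatic carbon. Among the compounds with values here, no measured step bears on this change, and none of the three values gives a number from which a direction could be read. Compound 4 is thus expected to sit at the same limit, with the step from compound 2 to compound 4 estimated as a step that the limit leaves unreadable from compound 2 to compound 4. The estimate for compound 4 in this assay is 200000 nM, within a range from 100000 nM to 1000000 nM.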

Compound 4, concentration for total growth inhibition: > 100000 nM
Compound 4: a limit, no number (the forecaster's own chance of this, stated with the estimate: 90%); the middle value lies beyond the limit too.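

The step from compound 2 to compound 4 cannot be read, because both ends are limits and not numbers: the limit of > 100000 nM in this assay, at which 4 of the 4 values shown sit.

The compounds shown leave open whether removing the methoxy, or any other change among compounds 1 to 4, alters growth inhibition in this assay at all.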